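A few compounds are considered here, and "the series" means these few. Any claim that something is new, unique, unknown or untested is made for them only; others in the source may bear on it.

Of the compounds shown here, three built on one shared core have been measured in a functional assay on A-375 cells (Homo sapiens) for antiproliferative activity, read by CCK-8 assay, with a stated time of 72 h, tested at 8 uM; a higher number here means a stronger effect of the compound at the concentration tested, a lower number a weaker effect. Compound 1 `Nc1ccccc1NC(=O)c1ccc(CSC(=S)N2CCc3ccccc32)cc1` gives 85.4%. Compound 2 `CC1CCN(C(=S)SCc2ccc(C(=O)Nc3ccccc3N)cc2)CC1` gives 87.4%, and compound 3 `Nc1ccccc1NC(=O)c1ccc(CSC(=S)N2CCCC2)cc1` gives 89.5%. On these numbers compound 1 stands at the low end of the three, yet every gap to it is small: the step of a number 2 percentage points higher from compound 1 to compound 2 (within the scatter) and the step of a number 4.1 percentage points higher from compound 1 to compound 3 (within the scatter) both lie within the scatter, as does a number 2.1 percentage points higher from compound 2 to compound 3 (within the scatter). Exchanging one amine for another on the thiocarbonyl carbon has so far produced nothing that can be told apart from repeat measurements.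

Compound 4 `Nc1ccccc1NC(=O)c1ccc(CSC(=S)N2CCc3cc([N+](=O)[O-])ccc32)cc1` keeps the amine of compound 1 and alters it in one place: nitro in place of hydrogen on an aromatic carbon. Within the data shown here, none of the measured steps bears directly on this ring; each of them replaced the whole amine, and each stayed within the scatter. There is therefore no basis for expecting a shift beyond the scatter in this assay in either direction, and the likeliest outcome is a number close to that of compound 1. Compound 4 is expected to give about 85%, between 70% and 95%. That estimate corresponds to an expected step of a number 0.4 percentage points lower from compound 1 to compound 4 (within the scatter).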

Compound 4, a percentage reported as inhibition, at one concentration (the size of the read-out at that concentration, not a potency): 29.5%
Beside the measured number, compound 4's estimate is 55.5 percentage points above it; the whole stated range lies above it.
By their numbers in this assay, from the lowest: compound 4; then compounds 1, 2 and 3 (each within the scatter of the next).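

The earlier steps shown here exchanged the whole amine on the thiocarbonyl carbon and stayed within the scatter, which made that end of the molecule look free to vary, but compound 4 shows that this freedom has a limit. In this assay, a single nitro of 3 heavy atoms on an aromatic carbon of the six-membered ring of carbon only gives a number 55.9 percentage points lower from compound 1 to compound 4 (beyond the scatter), a far larger step than any exchange of one whole amine for another among compounds 1, 2 and 3. So the outcome in this series can depend on one substituent on this ring, even though replacing the entire amine has so far made no measurable difference, and nothing available here explains why the nitro has this effect.

Going by these compounds, it remains open whether the loss belongs to nitro itself or would follow any group on this carbon, and a chlorine, a methoxy or an amino group in the same place would help separate those two readings. On these data alone, it is also open whether nitro on another carbon of this ring would give a step of similar size.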